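A few compounds are considered here, and "the series" means these few. Any claim that something is new, unique, unknown or untested is made for them only; others in the source may bear on it.

Measured so far in a functional assay (aorta) with Rattus norvegicus as the target; a higher number here means a more potent compound, by a factor of ten per unit of this negative logarithm, a lower number a less potent compound:

Compound 1, `COc1ccc2c(c1)C(n1ccccc1=O)=CC(C)(C)O2`: compound 1 gives 6.55.
Compound 2, `CC1(C)C=C(n2ccccc2=O)c2cc(C(=O)c3ccccc3F)ccc2O1`: compound 2 gives 7.08.

Compound 2 stands highest of the two numbers measured. Among the measured compounds shown here, its only neighbour is compound 1, and the step of a number 0.53 log units higher from compound 1 to compound 2 (beyond the scatter) is a modest rise beyond the scatter that comes with (2-fluorophenyl)carbonyl in place of methoxy on an aromatic carbon.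

Compound 3, `Cc1ccccc1C(=O)c1ccc2c(c1)C(n1ccccc1=O)=CC(C)(C)O2`, has not yet been measured. It differs from compound 2 in one place: methyl in place of fluoro on an aromatic carbon. The change sits on the six-membered aromatic ring of carbon only, ortho to a large group.

For the measured compounds named here, no measured step bears on this kind of exchange. Going by the values given here, the single step on hand replaces a whole group at a different place and says nothing about swapping fluoro for methyl on the outer ring. With nothing to point either way, the expectation in this assay is no step beyond the scatter. Compound 3 is therefore expected to give about 7, somewhere between 6.5 and 7.5. The step this estimate implies, a number 0.08 log units lower from compound 2 to compound 3 (within the scatter), is expected to lie within the usual scatter.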

Compound 3, logarithm of the reciprocal of the active concentration, log(1/C): 6.83
Estimate against measurement, compound 3: 0.17 log units above; measured number inside the range.
By their numbers in this assay, from the lowest: compounds 1, 3 and 2 (each within the scatter of the next, the first and the last beyond it).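

In this assay, methyl in place of fluoro on this aromatic carbon, ortho to a large group, gives a small step (a number 0.25 log units lower from compound 2 to compound 3 (within the scatter)), so the measurement does not separate these two groups at this position. The comparison with the methoxy compound is less clear-cut: (2-methylphenyl)carbonyl in place of methoxy gives a step inside the scatter (a number 0.28 log units higher from compound 1 to compound 3 (within the scatter)), whereas (2-fluorophenyl)carbonyl in place of methoxy gave one beyond it (a number 0.53 log units higher from compound 1 to compound 2 (beyond the scatter)), so only the fluoro compound stands clearly apart from compound 1. No measurement at hand offers an explanation for these numbers.

Fluoro and methyl each count one heavy atom and no hydrogen-bond donors or acceptors, so it remains open how an amine or a carboxylic acid would read at this same place. Also open, from the compounds shown here alone, is what the ring would give with only a hydrogen on this carbon, which would show whether either group adds anything at all.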